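The source may report more compounds than this note shows. Statements on the series, on what has been measured and on what is new or still open speak of the compounds shown alone.

Compounds measured so far:
compound 1, `COc1cc2nccc(Oc3ccc4c(NC(=O)Nc5ccc(C(F)(F)F)cc5Cl)nn(C)c4c3)c2cc1OC`, 1150 nM
compound 2, `COc1cc2nccc(Oc3ccc4c(NC(=O)c5cccc(C)c5)nn(C)c4c3)c2cc1OC`, 2 nM

In a functional assay on HUVEC cells (Homo sapiens) for inhibition, with stated times of 2 h and 72 h (on this read-out higher numbers stand for weaker inhibition and lower numbers for stronger inhibition), compound 2 gives the lowest number of the two, and the gap to compound 1 is wide: a 580-fold lower number from compound 1 to compound 2 (2.76 log units; beyond the scatter). Compound 3, `COc1cc2nccc(Oc3ccc4c(NC(=O)c5ccc(C(F)(F)F)cc5)nn(C)c4c3)c2cc1OC`, has not been measured. It differs from compound 2 in one place: 4-(trifluoromethyl)phenyl in place of 3-methylphenyl on a carbonyl carbon. Among the compounds with values here, the only measured step, from compound 1 to compound 2, replaces a whole aryl-amino group on the carbonyl carbon and changes the ring substitution at the same time, so it does not isolate the swap of one aryl group for another. Within the data shown here, no step that bears directly on this change is available. The expectation for compound 3 is therefore a modest rise at most, a 4.0-fold higher number from compound 2 to compound 3 (0.60 log units; beyond the scatter), with a range wide enough to cover no change. Compound 3 is estimated at 8 nM, between 2 nM and 40 nM.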

Compound 3, half-maximal inhibitory concentration: 79 nM
The estimate for compound 3 lay 9.9-fold (0.99 log units) below the measured number; the measured number lies above the stated range.
By their numbers in this assay, from the lowest: compound 2; then compound 3; then compound 1.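

In this assay, the aryl group on the carbonyl carbon matters even when the amide link stays the same: 4-(trifluoromethyl)phenyl in place of 3-methylphenyl gives a 40-fold higher number from compound 2 to compound 3 (1.60 log units; beyond the scatter), so this position does not accept every aryl group equally. Replacing the (2-chloro-4-(trifluoromethyl)phenyl)amino group with 4-(trifluoromethyl)phenyl gives a 15-fold lower number from compound 1 to compound 3 (1.16 log units; beyond the scatter), a large step but smaller than a 580-fold lower number from compound 1 to compound 2 (2.76 log units; beyond the scatter), so the outcome of replacing that group depends on which aryl group enters. Nothing available explains why these groups differ.

The swap from compound 2 to compound 3 alters both the substituent and its printed ring position, and the compounds shown cannot separate the two; 4-methylphenyl or 3-(trifluoromethyl)phenyl would bear on this. From the compounds shown here alone, how a phenyl ring carrying an amine or a carboxylic acid would behave here also stays open.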